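Replacing the 3-nitrophenyl Group in a Cytotoxicity Series

A few compounds are considered here, and "the series" means these few. Any claim that something is new, unique, unknown or untested is made for them only; others in the source may bear on it.

In a functional assay on C8166 cells (Homo sapiens) for cytotoxicity, read by MTT assay (a higher number here means that more compound is tolerated, a lower number that less compound is tolerated), compound 1 `Cc1cc(S(N)(=O)=O)ccc1NC(=O)COc1ccc(Cl)cc1NC(=O)c1ccccc1` gives 207000 nM, while compound 2 `Cc1cc(S(N)(=O)=O)ccc1NC(=O)COc1ccc(Cl)cc1NC(=O)c1cccc([N+](=O)[O-])c1` gives 58800 nM, the lower of the two numbers. Compound 3 `Cc1ccc(C(=O)Nc2cc(Cl)ccc2OCC(=O)Nc2ccc(S(N)(=O)=O)cc2C)cc1C` differs from compound 2 at one place: 3,4-dimethylphenyl in place of 3-nitrophenyl on a carbonyl carbon, with 3,4-dimethylphenyl in place of 3-nitrophenyl on a carbonyl carbon. Within the data shown here, the only measured step that bears on this is the modest 3.5-fold lower number from compound 1 to compound 2 (0.55 log units; beyond the scatter), where nitro replaced hydrogen on an aromatic carbon. Among the measured compounds shown here, no measurement yet shows what 3,4-dimethylphenyl does. Losing the nitro is expected to reverse part of that step, giving a higher number, a 2.1-fold higher number from compound 2 to compound 3 (0.33 log units; beyond the scatter). The estimate for compound 3 is 125000 nM, with an expected range of 50000 nM to 300000 nM.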

Compound 3, half-maximal cytotoxic concentration: 84100 nM
Compound 3: middle estimate off by 1.5-fold (0.17 log units), on the high side; the measured number falls inside the stated range.
By their numbers in this assay, from the lowest: compounds 2 and 3 (each within the scatter of the next); then compound 1.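

In this assay, 3,4-dimethylphenyl in place of 3-nitrophenyl on the carbonyl carbon gives a 1.4-fold higher number from compound 2 to compound 3 (0.16 log units; within the scatter) and so the two groups cannot be told apart at this position. Set against the plain phenyl, 3,4-dimethylphenyl gives a 2.5-fold lower number from compound 1 to compound 3 (0.39 log units; beyond the scatter) and so the lower number does not depend on the nitro group alone. No measured evidence explains either step.

Which of the two methyl groups matters, and whether one alone would do, stays open. So does the effect of an amine or a carboxylic acid on this ring.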